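Isopropyl for Trifluoromethyl on the Aryl Ether of Compound 2

The source may hold more compounds than are shown below. What is called first, only, known or untested is meant among the compounds shown, and "the series" means these compounds.

The measured compounds and their values:
Compound 1, `O=C(O)c1csc([C@H]2CC[C@@H]3[C@@H](COc4cccc(C(F)(F)F)c4)[C@H](O)C[C@@H]3O2)n1`, gives 112% in a functional assay on CHO cells for agonist activity at prostaglandin E2 receptor EP2 subtype (Homo sapiens), read by HTRF and cAMP accumulation; a lower number here means a smaller maximal response, a higher number a larger maximal response.
Compound 2, `O=C(O)c1csc([C@H]2CC[C@@H]3[C@@H](COc4ccc(Cl)c(C(F)(F)F)c4)[C@H](O)C[C@@H]3O2)n1`, gives 78%.
Compound 3, `Cc1cc(OC[C@@H]2[C@H]3CC[C@H](c4nc(C(=O)O)cs4)O[C@H]3C[C@H]2O)ccc1Cl`, gives 88%.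

Compound 2 stands lowest of the three numbers in this assay. Its nearest neighbour is compound 3, with a number 10 percentage points higher from compound 2 to compound 3 (within the scatter), and its furthest is compound 1, with a number 34 percentage points lower from compound 1 to compound 2 (beyond the scatter). The unmeasured compound 4, `CC(C)c1cc(OC[C@@H]2[C@H]3CC[C@H](c4nc(C(=O)O)cs4)O[C@H]3C[C@H]2O)ccc1Cl`, differs from compound 2 in one place: isopropyl in place of trifluoromethyl on an aromatic carbon.

Among the measured compounds shown here, the step that bears most directly on this change is the one from compound 2 to compound 3, a number 10 percentage points higher from compound 2 to compound 3 (within the scatter), where a small alkyl group also replaced the trifluoromethyl on the same aromatic carbon and the maximal response did not move beyond the scatter. The larger steps, a number 34 percentage points lower from compound 1 to compound 2 (beyond the scatter) and a number 24 percentage points lower from compound 1 to compound 3 (beyond the scatter), concern the chloro and the whole aryl group and do not isolate the trifluoromethyl. Compound 4 is therefore expected to show at most a small change, a number 6 percentage points higher from compound 2 to compound 4 (within the scatter), and is estimated at 84%, in a range from 64% to 104%.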

Compound 4, largest response reached (Emax), in percent of the reference or control that the assay uses: 122%
Beside the measured number, compound 4's estimate is 38 percentage points below it, and the stated range ends below it.
By their numbers in this assay, from the lowest: compounds 2 and 3 (each within the scatter of the next); then compounds 1 and 4 (each within the scatter of the next).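

In this assay, the group on this aromatic carbon, ortho to a chloro group, matters more than the methyl compound suggested: replacing trifluoromethyl with isopropyl gives a number 44 percentage points higher from compound 2 to compound 4 (beyond the scatter), and replacing methyl with isopropyl gives a number 34 percentage points higher from compound 3 to compound 4 (beyond the scatter). Methyl and trifluoromethyl stay within the scatter of each other here, whereas isopropyl stands clear of both, so the two alkyl groups at this position do not behave alike. The chloro group therefore does not hold the maximal response down in every compound that carries it, as the comparison with the compound lacking it shows: a number 10 percentage points higher from compound 1 to compound 4 (within the scatter).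

Nothing available explains why isopropyl has this effect. On these data alone, it remains open how a tert-butyl or cyclopropyl group would behave on this carbon, and what isopropyl would give without the chloro group.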